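The compounds below may be only part of what the source reports. "The series", "measured", "known", "first", "only" and "open" are said of these compounds alone.

Measured compounds:
- compound 1, `O=c1ccc(-c2ccc3cn[nH]c3c2)cn1Cc1ccccc1C(F)(F)F`, 100 nM
- compound 2, `Nc1n[nH]c2cc(-c3ccc(=O)n(Cc4cccc(Cl)c4)c3)ccc12`, 6 nM
- compound 3, `Nc1n[nH]c2cc(-c3ccc(=O)n(Cc4cccc(F)c4)c3)ccc12`, 5 nM

All three were tested in an assay for inhibition of MAP kinase-interacting serine/threonine-protein kinase 2 (Homo sapiens), read by luminescence and ADP-Glo, with a stated time of 2 h; a higher number here means a weaker inhibitor, a lower number a stronger inhibitor. Compound 1 gives the highest of the three numbers and is therefore the weakest inhibitor here; compound 2 and compound 3 both sit well beyond the scatter below it. Compound 2 and compound 3 differ from each other only in one place, and that step, a 1.2-fold lower number from compound 2 to compound 3 (0.08 log units; within the scatter), is within the scatter. Both of them differ from compound 1 in more than one place, so their gap to compound 1 cannot be assigned to any single change.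

Compound 4, `O=c1ccc(-c2ccc3cn[nH]c3c2)cn1Cc1ccccc1Cl`, has not yet been measured. It differs from compound 1 by chloro in place of trifluoromethyl on an aromatic carbon, ortho to a large group. Within the data shown here, no measured step matches this swap. Among the measured compounds shown here, the only measured change on that ring, from compound 2 to compound 3, exchanged one halogen for another and stayed within the scatter; it says nothing about replacing trifluoromethyl. On this basis compound 4 is expected to stay near compound 1, with no change at the digits printed from compound 1 to compound 4 (within the scatter) as the estimated step, and no direction is favoured beyond the scatter. The value estimated for compound 4 is 100 nM, within a range from 40 nM to 300 nM.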

Compound 4, half-maximal inhibitory concentration: 78 nM
The estimate for compound 4 lay 1.3-fold (0.11 log units) above the measured number, and the stated range covers the measured number.
By their numbers in this assay, from the lowest: compounds 3 and 2 (each within the scatter of the next); then compounds 4 and 1 (each within the scatter of the next).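

In this assay, chloro in place of trifluoromethyl on an aromatic carbon, ortho to a large group, gives a 1.3-fold lower number from compound 1 to compound 4 (0.11 log units; within the scatter) and so shows that, in this pair, a group of 4 heavy atoms can be exchanged for one of 1 heavy atom without a change that can be told from the scatter. Among these compounds, the earlier one-place step exchanged one halogen for another in a different pair of compounds, so this is the first measured step that removes trifluoromethyl, and the first measured step at this place on the core of compound 1. No measurement is available that would explain why the two groups give numbers so close together at this place.

Still open, as far as these compounds go, is whether a group of another kind at this place, such as a methoxy group, an amine or a carboxylic acid, would also leave the number within the scatter or would move it clearly. Also open, from the compounds shown here alone, is whether chloro and trifluoromethyl would stay this close on the core of compound 2, which carries an amino group that compound 1 lacks.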